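This account rests on a few compounds, and the source may have more. Where it says the series, first, only, none or still open, it means among the compounds named here.

Compound 1 `O=C(Nc1ccc2nc(NC(=O)C3CCCCC3)sc2c1)c1cccc(Oc2ccccc2)c1`: > 4 ug/mL in the cytotoxicity read-out, a limit of the assay rather than a number.
Compound 2 `O=C(Nc1nc2ccc(NC(=O)C3CCCO3)cc2s1)C1CCCCC1`: 1.3 ug/mL
Compound 3 `COC(=O)Nc1nc2ccc(NC(=O)c3c(Cl)cccc3Cl)cc2s1`: 0.0095 ug/mL

In a functional assay on WI-38 VA13 cells (Homo sapiens) for cytotoxicity (on this read-out higher numbers stand for an effect only at larger amounts of compound and lower numbers for an effect already at smaller amounts), compound 3 holds the lowest of the two numbers shown. Its nearest neighbour is compound 2, which gives 1.3 ug/mL in this assay, a gap well beyond the usual scatter. For compound 1 this assay reports only a limit, > 4 ug/mL; that reading is a limit and no number, so it cannot be placed against the other two in size.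

The step now followed leads from compound 3 to compound 4 `CCCCNC(=O)Nc1nc2ccc(NC(=O)c3c(Cl)cccc3Cl)cc2s1`, which is not yet measured in this assay. The change is butylamino in place of methoxy on a carbonyl carbon. No measured pair among the three compounds differs only in this place, so there is no shown step to lean on, and the expectation has to rest on compound 3 alone, whose value in this assay is 0.0095 ug/mL.

With nothing in the shown data pointing either way, compound 4 is expected to remain close to compound 3, with the estimated step from compound 3 to compound 4 being a 3.2-fold higher number from compound 3 to compound 4 (0.50 log units; beyond the scatter), a change not clearly beyond the scatter. Compound 4 is therefore estimated at 0.03 ug/mL in this assay, within a range from 0.005 ug/mL to 0.3 ug/mL.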

Compound 4, half-maximal effective concentration: 0.028 ug/mL
The estimate for compound 4 lay 1.1-fold (0.03 log units) above the measured number; the measured number falls inside the stated range.
By their numbers in this assay, from the lowest: compound 3; then compound 4; then compound 2. At a limit, above all of these: compound 1.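

This is the first pair among the compounds shown that differs in a single place, and so the first direct reading of the group on this carbonyl carbon: in this assay, butylamino in place of methoxy gives a 2.9-fold higher number from compound 3 to compound 4 (0.47 log units; beyond the scatter) (the shared core and the dichlorophenyl amide stay the same). The step is beyond the scatter but modest, so this position accepts a change from methoxycarbonyl to butylcarbamoyl, with its larger count of heavy atoms and its hydrogen-bond donor, and compound 4 still acts at small amounts of compound. Nothing shown gives a reason for the size of this step.

The step changes two things at once, the oxygen for a nitrogen and the methyl for a butyl chain, so the compounds shown cannot tell which of the two accounts for it. Still open, on these data alone, is how this position would respond to a shorter methylamino group, a longer chain, a ring such as morpholine, or a butyl chain ending in an amine or a carboxylic acid.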